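Swapping the Methoxypiperidine Amide for a Methoxypyrrolidine

The source may hold more compounds than are shown below. What is called first, only, known or untested is meant among the compounds shown, and "the series" means these compounds.

Measured compounds:
Compound 1 `CCN(CC)S(=O)(=O)c1ccc(S(=O)(=O)N2CCC[C@@H](C(=O)N3CCC(OC)CC3)C2)cc1`: 140 nM
Compound 2 `CC(C)S(=O)(=O)c1ccc(S(=O)(=O)N2CCC[C@@H](C(=O)N3CCC(F)(F)CC3)C2)cc1`: 11 nM
Compound 3 `CN(C)S(=O)(=O)c1ccc(S(=O)(=O)N2CCC[C@@H](C(=O)N3CCC(F)(F)CC3)C2)cc1`: 118 nM

In a functional assay on MIA PaCa-2 cells (Homo sapiens) for inhibition, read by MTT assay, with a stated time of 7 days (on this read-out lower numbers stand for stronger inhibition and higher numbers for weaker inhibition), compound 1 gives the highest of the three numbers. Compound 3 lies nearest to it, at a gap that falls within the scatter, whereas compound 2 lies far below it, beyond the scatter. Among the compounds with values here, the only single-point step measured so far, an 11-fold higher number from compound 2 to compound 3 (1.03 log units; beyond the scatter), concerns the group on the sulfonyl sulfur and says nothing about the carbonyl carbon of the shared core.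

Compound 4 `CCN(CC)S(=O)(=O)c1ccc(S(=O)(=O)N2CCC[C@@H](C(=O)N3CC[C@@H](OC)C3)C2)cc1` differs from compound 1 at that carbonyl carbon: 3-methoxypyrrolidin-1-yl in place of 4-methoxypiperidin-1-yl on a carbonyl carbon. Within the data shown here, no measured step bears on this change, and the remaining compounds differ from compound 1 elsewhere as well. Nothing in the data therefore argues for a shift in either direction in this assay beyond the scatter. Compound 4 is expected to land close to compound 1, with the step of no change at the digits printed from compound 1 to compound 4 (within the scatter) expected to remain within the scatter. The estimate for compound 4 is 140 nM, with a range from 50 nM to 400 nM.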

Compound 4, half-maximal inhibitory concentration: 3910 nM
Estimate against measurement, compound 4: 28-fold (1.45 log units) below, outside the stated range (above it).
By their numbers in this assay, from the lowest: compound 2; then compounds 3 and 1 (each within the scatter of the next); then compound 4.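

In this assay, the group on the carbonyl carbon turns out to matter: 3-methoxypyrrolidin-1-yl in place of 4-methoxypiperidin-1-yl gives a 28-fold higher number from compound 1 to compound 4 (1.45 log units; beyond the scatter). Within the data shown here, the earlier compounds showed a step beyond the scatter only at the sulfonyl sulfur, so this is the first sign that the amide end of the shared core is also sensitive to change, at least for this pair. No measurement offered here accounts for the loss.

The step replaces a six-membered ring with a five-membered one and brings in a defined stereocentre at the same time, and the compounds shown do not separate these changes. An unsubstituted pyrrolidin-1-yl, 3-methoxypiperidin-1-yl or the opposite stereoisomer of 3-methoxypyrrolidin-1-yl would be needed to tell them apart.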